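Replacing the Sulfonyl Group with Cyclohexylcarbonyl

The compounds below may be only part of what the source reports. "The series", "measured", "known", "first", "only" and "open" are said of these compounds alone.

In an ADME assay on microsomes from liver (Homo sapiens) for metabolic stability, with a stated time of 10 min, tested at 0.5 uM (on this read-out higher numbers stand for a more stable compound and lower numbers for a less stable compound), compound 3 `C[C@@H](NS(=O)(=O)c1ccc(Cl)cc1)[C@H]1CC[C@@H](c2ccnc3ccc(F)cc32)CC1` gives 29%, the lower of the two values that are actual numbers, while compound 2 `C[C@@H](CNc1ccc(Cl)cc1)[C@H]1CC[C@@H](c2ccnc3ccc(F)cc32)CC1` gives 80%. Compound 1 `C[C@@H](C(=O)NC1CCCCC1)[C@H]1CC[C@@H](c2ccnc3ccc(F)cc32)CC1` reads < 1%, which is a limit of the assay. Compound 4 `C[C@@H](NC(=O)C1CCCCC1)[C@H]1CC[C@@H](c2ccnc3ccc(F)cc32)CC1` carries cyclohexylcarbonyl in place of (4-chlorophenyl)sulfonyl on an amine nitrogen. Among the measured compounds shown here, the one measured step that bears on this change is a number at least 79 percentage points higher from compound 1 to compound 2 (beyond the scatter), which took away the cyclohexylcarbamoyl group of compound 1, the only measured compound with a cyclohexyl ring and a carbonyl. On that basis, a fall beyond the scatter is expected in this assay, an estimated a number 21 percentage points lower from compound 3 to compound 4 (beyond the scatter). Compound 4 is estimated at 8%, within a range of 1% to 30%.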

Compound 4, percent of the compound remaining: 6%
Compound 4: middle estimate off by 2 percentage points, on the high side; the range from low to high includes it.
By their numbers in this assay, from the lowest: compound 4; then compound 3; then compound 2. At a limit, below all of these: compound 1.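

In this assay cyclohexylcarbonyl in place of (4-chlorophenyl)sulfonyl on an amine nitrogen gives a number 23 percentage points lower from compound 3 to compound 4 (beyond the scatter). Against the ((4-chlorophenyl)amino)methyl of compound 2, (cyclohexylcarbonyl)amino gives a number 74 percentage points lower from compound 2 to compound 4 (beyond the scatter). The step that starts from a limit of the assay gives a number at least 5 percentage points higher from compound 1 to compound 4 (that floor lies within the scatter) and cannot be read as a change: the limit of < 1% in this assay, at which 1 of the 4 values shown sits.

Going by these compounds, what stays open is whether the lower number goes with the cyclohexyl ring or with the carbonyl. A benzoyl group or a cyclohexylsulfonyl group on the same nitrogen would separate the two.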